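From 2-fluorophenyl to benzyl: clearance of compound 3

The source may report more compounds than this note shows. Statements on the series, on what has been measured and on what is new or still open speak of the compounds shown alone.

Results in an ADME assay on liver for metabolic stability, with Liver microsome (Homo sapiens) as the target, read by LC-MS, using microsomes (a higher number here means faster removal of the compound, a lower number slower removal), are these:
- compound 1 `COC(C)(C)[C@@H](O)C(=O)N1C[C@H]2C[C@H]2[C@H]1C(=O)NCc1cc(Cl)ccc1-n1cnnn1` gives 23 mL.min-1.g-1
- compound 2 `O=C(NCc1cc(Cl)ccc1-n1cnnn1)[C@@H]1[C@@H]2C[C@@H]2CN1C(=O)[C@H](O)c1ccccc1F` gives < 12 mL.min-1.g-1 (a limit of the assay, not a number)

Compound 2 is reported with < 12 mL.min-1.g-1 as a limit of the assay, so no exact figure exists for it. The results hold the limit of < 12 mL.min-1.g-1 in this assay, at which 1 of the 2 values shown sits, and no finer reading for compound 2.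

Compound 3 `O=C(NCc1cc(Cl)ccc1-n1cnnn1)[C@@H]1[C@@H]2C[C@@H]2CN1C(=O)[C@H](O)Cc1ccccc1` differs from compound 2 in one group: benzyl in place of 2-fluorophenyl on a saturated chain carbon bound to a carbonyl carbon and an oxygen on a saturated carbon.

Among the compounds with values here, only one measured step touches that place, an at least 1.9-fold lower number from compound 1 to compound 2 (0.28 log units; that floor lies within the scatter) and it is a loose guide, since benzyl itself has not been measured there. Within the data shown here, with compound 1 at 23 mL.min-1.g-1 as the only full number, compound 3 is expected to stay in the same low range, perhaps slightly higher. The expected step is an at least 1.1-fold higher number from compound 2 to compound 3 (0.06 log units; that floor lies within the scatter) and it is not expected to clearly pass the scatter in this assay (a further limit is possible). For compound 3 the estimated value is 14 mL.min-1.g-1 within an expected range (9 mL.min-1.g-1 to 28 mL.min-1.g-1).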

Compound 3, intrinsic clearance in microsomes: 74 mL.min-1.g-1
Compound 3: the middle estimate sits 5.3-fold (0.72 log units) below what was measured, and the stated range ends below it.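

In this assay, this place on the molecule proves sensitive to a small change: 2-fluorophenyl and benzyl each carry one six-membered aromatic ring of carbon only, yet the swap gives an at least 6.1-fold higher number from compound 2 to compound 3 (0.79 log units; beyond the scatter). Benzyl also separates from the 1-methoxy-1-methylethyl group, with a 3.2-fold higher number from compound 1 to compound 3 (0.51 log units; beyond the scatter), so among these three groups on the shared core, only benzyl is clearly removed faster than both of the others. The first of these steps gives only a floor, not an exact size, as compound 2 is reported as a limit of the assay rather than a number: the limit of < 12 mL.min-1.g-1 in this assay, at which 1 of the 3 values shown sits.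

The swap from 2-fluorophenyl to benzyl removes the fluorine and adds a carbon to the link at the same time, so the compounds shown cannot tell which of the two matters; a plain phenyl or a 2-fluorobenzyl group at this place would separate them. Also open, going by these compounds, is whether a longer chain ending in the same ring, such as 2-phenylethyl, would push the number higher still, and where on compound 3 the removal actually takes place.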